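A few compounds are considered here, and "the series" means these few. Any claim that something is new, unique, unknown or untested is made for them only; others in the source may bear on it.

Compound 1 `C=C(C)C(=O)N(Cc1ccc(OC)c(O)c1)c1cc(OC)c(OC)c(OC)c1` — 390 nM
Compound 2 `COc1ccc(N(Cc2cc(OC)c(OC)c(OC)c2)C(=O)CN=[N+]=[N-])cc1O` — 22400 nM

Of the compounds shown here, two have been measured in a functional assay on MGC-803 cells (Homo sapiens) for inhibition, read by MTT assay, with a stated time of 48 h; a lower number here means a stronger inhibitor, a higher number a weaker inhibitor. Compound 1 gives 390 nM in this assay, the lowest of the two numbers and therefore the stronger inhibitor of the pair. Among the measured compounds shown here, compound 2, whose number in this assay is 22400 nM, stands far behind it, a gap well beyond the scatter of the method; no single step joins these two structures, so only their two values can be compared.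

Compound 3 `COc1ccc(CN(C(=O)C2CC2)c2cc(OC)c(OC)c(OC)c2)cc1O` has not been measured yet. It keeps the core of compound 1 and the same atoms, joined differently: cyclopropyl in place of 1-methylethenyl on a carbonyl carbon. The change sits on a carbonyl carbon whose other neighbour is the amide-type nitrogen; a 1-methylethenyl group with one double bond outside aromatic rings leaves, and a cyclopropyl with one three-membered non-aromatic ring of carbon only enters.

Without a measured step of this kind, the expectation rests on compound 1 alone. Compound 3 is expected to give a higher number than compound 1, a step of a 5.1-fold higher number from compound 1 to compound 3 (0.71 log units; beyond the scatter) beyond the scatter. The estimate for compound 3 in this assay is 2000 nM, with a range from 500 nM to 10000 nM.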

Compound 3, half-maximal inhibitory concentration: 59 nM
The estimate for compound 3 lay 34-fold (1.53 log units) above the measured number; measured number outside the range, below it.
By their numbers in this assay, from the lowest: compound 3; then compound 1; then compound 2.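

In this assay, cyclopropyl in place of 1-methylethenyl on a carbonyl carbon gives a 6.6-fold lower number from compound 1 to compound 3 (0.82 log units; beyond the scatter). Among the compounds shown here, this is the first comparison here between compounds that differ in one place, and it shows that the group on this carbonyl carbon affects the result even when the atoms stay the same: one double bond outside aromatic rings leaves, a three-membered ring of carbon enters, and the number falls. No measured evidence is available to explain this difference.

Two explanations of the pattern remain possible: the lower number may go with the presence of the three-membered ring or with the loss of the double bond, and an isopropyl group or a cyclobutyl ring on the same carbonyl carbon would help to tell these apart. The compounds shown also leave open how an amine or a longer carbon chain would fare at this position, and whether the same exchange would lower the number on a different core.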